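The source may report more compounds than this note shows. Statements on the series, on what has been measured and on what is new or still open speak of the compounds shown alone.

Measured so far in a functional assay on A549 cells (Homo sapiens) for antiproliferative activity, read by MTT assay, with a stated time of 72 h; a lower number here means a stronger inhibitor, a higher number a weaker inhibitor:
compound 1 `CCn1cc(C(=O)O)c(=O)c2cc(F)c(N3CCN(C(=N)NS(=O)(=O)c4ccccc4Cl)CC3)cc21` gives 71 nM;
compound 2 `N=C(NS(=O)(=O)c1ccccc1Cl)N1CCN(c2cc3c(cc2F)c(=O)c(C(=O)O)cn3C2CC2)CC1` gives 71 nM;
compound 3 `N=C(NS(=O)(=O)c1ccccc1C(F)(F)F)N1CCN(c2cc3c(cc2F)c(=O)c(C(=O)O)cn3C2CC2)CC1` gives 71 nM.

Compound 1 stands level with compounds 2 and 3: all three values fall together, and neither the step of no change at the digits printed from compound 1 to compound 2 (within the scatter) nor the step of no change at the digits printed from compound 2 to compound 3 (within the scatter) reaches beyond the scatter of repeat measurement. Nothing in these three results separates one compound from another.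

Compound 4 `CCn1cc(C(=O)O)c(=O)c2cc(F)c(N3CCN(C(=N)NS(=O)(=O)c4ccc(C)cc4)CC3)cc21` has not yet been measured. It differs from compound 1 at one place: 4-methylphenyl in place of 2-chlorophenyl on a sulfonyl sulfur. The change therefore falls on the aryl group of the sulfonyl, the same region that is altered in the step from compound 2 to compound 3, where exchanging chloro for trifluoromethyl left the value unchanged. The step from compound 1 to compound 2, which alters a different part of the molecule, was likewise flat. With two flat steps and nothing pointing either way, the expectation for compound 4 is no movement beyond the scatter, written as no change at the digits printed from compound 1 to compound 4 (within the scatter).

On that basis compound 4 is estimated to give 71 nM, with a range from 35 nM to 140 nM in this assay.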

Compound 4, half-maximal inhibitory concentration: 71 nM
Estimate against measurement, compound 4: no gap at the digits printed; the measured number falls inside the stated range.
By their numbers in this assay, from the lowest: compounds 1, 2, 3 and 4 (each within the scatter of the next).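

In this assay, putting 4-methylphenyl in place of 2-chlorophenyl on the sulfonyl sulfur gives no change at the digits printed from compound 1 to compound 4 (within the scatter). The earlier step at this aryl group exchanged one substituent for another under the same position number, whereas this one also changes the number in the group's name, from 2 to 4, and the ring loses its chlorine and now holds carbon only, so this value holds across a wider change to the aryl group than compounds 2 and 3 alone could show. No measurement offered here explains why the value stays level across these changes.

Each aryl group among these compounds is a phenyl ring carrying a single substituent, so it remains open whether a bare phenyl, a phenyl bearing an amine or a methoxy group, or a straight alkyl chain in place of the ring would also leave the value level. The compounds shown also leave open how 4-methylphenyl behaves with cyclopropyl on the aromatic nitrogen, and whether a methyl ester in place of the carboxylic acid would shift the value.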